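Adding a chloro group to compound 3

The source may hold more compounds than are shown below. What is called first, only, known or untested is meant among the compounds shown, and "the series" means these compounds.

Measured in a functional assay on HeLa cells (Homo sapiens) for inhibition, read by sulforhodamine B assay; a lower number here means a stronger inhibitor, a higher number a weaker inhibitor:
Compound 1 `O=C1C=C(Nc2cccc(F)c2)C(=O)c2c1nc1n2[C@H]2OC[C@@H](O)[C@H]2OC1`: 6440 nM
Compound 2 `CCOc1ccccc1NC1=CC(=O)c2nc3n(c2C1=O)[C@H]1OC[C@@H](O)[C@H]1OC3`: 6040 nM
Compound 3 `O=C1C=C(Nc2ccccc2)C(=O)c2c1nc1n2[C@H]2OC[C@@H](O)[C@H]2OC1`: 5620 nM

Compound 3 gives 5620 nM, which cannot be told apart from the other two values, since all three lie within the normal scatter of repeat measurements. Compound 4 `O=C1C=C(Nc2cccc(Cl)c2)C(=O)c2c1nc1n2[C@H]2OC[C@@H](O)[C@H]2OC1` keeps the shared core and swaps phenyl for 3-chlorophenyl, with chloro in place of hydrogen on an aromatic carbon, meta to a large group: chloro in place of hydrogen on an aromatic carbon.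

For the measured compounds named here, no chloro compound has been measured yet. The closest guide is compound 1, a 3-fluorophenyl compound, which shows a 1.1-fold lower number from compound 1 to compound 3 (0.06 log units; within the scatter). Compound 2, with its 2-ethoxyphenyl group, shows a 1.1-fold lower number from compound 2 to compound 3 (0.03 log units; within the scatter). Both steps are within the scatter, so these substituents have so far left the number in this assay essentially unmoved. The expected result is a 1.0-fold higher number from compound 3 to compound 4 (0.01 log units; within the scatter), a step no larger than the scatter.

The estimate for compound 4 is 5800 nM, with an expected range of 2900 nM to 11500 nM.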

Compound 4, half-maximal inhibitory concentration: 6040 nM
Beside the measured number, compound 4's estimate is 1.0-fold (0.02 log units) below it; the range from low to high includes it.
By their numbers in this assay, from the lowest: compounds 3, 2, 4 and 1 (each within the scatter of the next).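

In this assay, putting chloro in place of hydrogen on the aromatic ring gives a 1.1-fold higher number from compound 3 to compound 4 (0.03 log units; within the scatter), so this heavier halogen leaves the number unmoved, as the earlier fluoro and ethoxy compounds did. Exchanging the halogen gives a 1.1-fold lower number from compound 1 to compound 4 (0.03 log units; within the scatter), and 3-chlorophenyl in place of 2-ethoxyphenyl gives no change at the digits printed from compound 2 to compound 4 (within the scatter), which places all four compounds within the scatter of one another and shows that this position has so far accepted each of these changes without a readable shift. Nothing available here explains why the number stays so flat.

Still open, from the compounds shown here alone, is whether any group on this ring can move the number at all, such as an amine, a carboxylic acid or a longer chain. Going by these compounds, all four compounds also share the same core, so what a change to that core would do remains unknown.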